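Swapping a triazolylmethyl for an imidazolyl group

This account rests on a few compounds, and the source may have more. Where it says the series, first, only, none or still open, it means among the compounds named here.

Compound 1, `CCC(CC)(c1nnc[nH]1)c1ccc(-c2ccc3cc(F)cc(F)c3c2)[nH]c1=O`, gives 350 nM in a functional assay on CHO cells for antagonist activity at prostaglandin E2 receptor EP3 subtype (Homo sapiens), read by cAMP accumulation; a lower number here means a stronger inhibitor, a higher number a weaker inhibitor.
Compound 2, `CC(C)C(O)(C(=O)O)c1ccc(-c2ccc3ccccc3c2)[nH]c1=O`, gives 1580 nM in this assay.
Compound 3, `CC(C)C(Cc1nnc[nH]1)c1ccc(-c2ccc3cccc(F)c3c2)[nH]c1=O`, gives 17 nM in this assay.

Among the three measured compounds, compound 3 has the lowest number in this assay, and its steps to compound 1 and compound 2 both lie beyond the usual scatter, so it is the strongest inhibitor of the set. Compound 4, `CC(C)C(c1ncc[nH]1)c1ccc(-c2ccc3cccc(F)c3c2)[nH]c1=O`, has not yet been measured. It differs from compound 3 in one place: 1H-imidazol-2-yl in place of (4H-1,2,4-triazol-3-yl)methyl on a saturated chain carbon bound to an aromatic carbon and a saturated chain carbon. Within the data shown here, no measured pair shows this exact change, so its size is not known. Compound 1, which also carries a five-membered ring directly on the chain carbon but differs in several other places as well, shows a far higher number than compound 3, which cannot be traced to any single change. The expectation for compound 4 is a moderate loss in this assay, a step of a 3.5-fold higher number from compound 3 to compound 4 (0.55 log units; beyond the scatter), with the estimated value 60 nM and a likely range from 15 nM to 300 nM.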

Compound 4, half-maximal inhibitory concentration: 33 nM
Compound 4: middle estimate off by 1.8-fold (0.26 log units), on the high side, and the stated range covers the measured number.
By their numbers in this assay, from the lowest: compounds 3 and 4 (each within the scatter of the next); then compound 1; then compound 2.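

In this assay, the exchange gives a 1.9-fold higher number from compound 3 to compound 4 (0.29 log units; within the scatter), so this first direct comparison at this position cannot tell the two groups apart. On this saturated chain carbon, then, a five-membered aromatic ring attached directly does as well in this assay as one held on a methyl link. The ring and the link change together in this step, however, so neither change can be judged alone, and nothing available explains why the two groups match.

A (1H-imidazol-2-yl)methyl group on the same carbon would help separate the effect of the ring from that of the link. As far as these compounds go, it also remains open whether the ring is needed at all, which a simple amine at this place could test.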